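The compounds below may be only part of what the source reports. "The series", "measured", "known", "first", "only" and "open" are said of these compounds alone.

In an assay on isolated protein for inhibition of Aromatase (Homo sapiens), read by fluorescence, using NADPH, with a stated time of 30 min, tested at 50 uM (a lower number here means less inhibition, a higher number more inhibition at the concentration tested (going by the name of the read-out)), three compounds have been measured so far:

compound 1, `O=[N+]([O-])c1ccc2[nH]c(-c3cccnc3)cc2c1`, gives 27.9%
compound 2, `COCn1c(-c2ccccc2)cc2ccccc21`, gives 20.2%
compound 3, `Nc1cccc(-c2cc3ccccc3[nH]2)c1`, gives 26.7%

All three share a fused two-ring core and carry a six-membered aromatic ring on the five-membered ring. Compound 2 has the lowest of the three numbers, but its gap to compound 3, the nearest, and to compound 1, the furthest, both fall within the usual scatter of this kind of measurement, so the three cannot be placed in any order; they sit together at a modest level of inhibition at the concentration tested.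

Compound 4, `CC(C)(C)OC(=O)n1c(-c2ccccc2)cc2ccccc21`, has not yet been measured. It differs from compound 2 in a single place: tert-butoxycarbonyl in place of methoxymethyl on an aromatic nitrogen. Both the group that leaves and the group that enters sit on the aromatic nitrogen of the five-membered ring, next to the ring atom that bears a phenyl group, and the rest of the molecule is unchanged.

Among the measured compounds shown here, no measured pair shows what such a swap on that nitrogen does, so nothing in the numbers points in either direction. The step of a number 1.8 percentage points higher from compound 2 to compound 4 (within the scatter) is therefore expected to stay within the scatter, in no particular direction. Compound 4 is estimated at 22%, with a range from 8% to 38%.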

Compound 4, a percentage reported as inhibition, at one concentration (the size of the read-out at that concentration, not a potency): 11.9%
The estimate for compound 4 lay 10.1 percentage points above the measured number; measured number inside the range.
By their numbers in this assay, from the lowest: compounds 4, 2, 3 and 1 (each within the scatter of the next, the first and the last beyond it).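

Among the compounds shown here, this is the first pair in this assay that differs only in the group on the aromatic nitrogen of the five-membered ring, and it gives a number 8.3 percentage points lower from compound 2 to compound 4 (within the scatter). Replacing methoxymethyl with tert-butoxycarbonyl adds heavy atoms, a hydrogen-bond acceptor and a double bond outside the aromatic rings, yet at this position the two compounds cannot be told apart by this measurement. Nothing measured here speaks to why the step has this size.

Still open, on these data alone, is whether a different group on that nitrogen, such as a plain methyl, a longer alkyl chain, or a chain ending in an amine or a carboxylic acid, would give a number clearly separate from those of compound 2 and compound 4. The pair also leaves open whether the same swap would give a similar step on a core with further groups on the phenyl ring or the fused rings, since both of these compounds carry none.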